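The source may hold more compounds than are shown below. What is called first, only, known or untested is meant among the compounds shown, and "the series" means these compounds.

Measured compounds:
compound 1, `COc1ccc(CCCCCC(=O)N2CCOC2=O)cc1`. In an assay on HEK293 cells for inhibition of N-acylethanolamine-hydrolyzing acid amidase (Rattus norvegicus), read by LC-MS, with a stated time of 30 min (on this read-out lower numbers stand for stronger inhibition and higher numbers for weaker inhibition), compound 1 reaches only > 20000 nM, which is a limit of the assay and not a number.
compound 2, `Nc1ccc(CCCCCC(=O)N2CCOC2=O)cc1`. In this assay compound 2 gives 15700 nM.

For the measured compounds named here, compound 2 holds the only numerical value in this assay; the other entry is a limit. The step of an at least 1.2-fold lower number from compound 1 to compound 2 (0.10 log units; that floor lies within the scatter) stays within the scatter, with the limit of > 20000 nM in this assay, at which 1 of the 2 values shown sits, marking where compound 1 sits.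

Compound 3, `O=C(CCCCCc1ccc(C(F)(F)F)cc1)N1CCOC1=O`, differs from compound 2 by trifluoromethyl in place of amino on an aromatic carbon. Going by the values given here, no measured step involves a trifluoromethyl group. The single measured step, an at least 1.2-fold lower number from compound 1 to compound 2 (0.10 log units; that floor lies within the scatter), exchanges two groups on the aromatic carbon and produces a change within the scatter, so this position has shown little sensitivity so far. On that basis the expected step in this assay is a 1.1-fold higher number from compound 2 to compound 3 (0.06 log units; within the scatter), within the scatter, with no direction beyond it.

Compound 3 is therefore estimated at 18000 nM, with a range from 6000 nM to 50000 nM. Given (the limit of > 20000 nM in this assay, at which 1 of the 2 values shown sits), a result reported only as a limit remains a real possibility for compound 3.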

Compound 3, half-maximal inhibitory concentration: 1040 nM
Estimate against measurement, compound 3: 17-fold (1.24 log units) above, outside the stated range (below it).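

The aromatic carbon para to a large group proves sensitive in this assay, which the earlier pair, with its step within the scatter, could not show: trifluoromethyl in place of amino gives a 15-fold lower number from compound 2 to compound 3 (1.18 log units; beyond the scatter). Trifluoromethyl in place of methoxy gives an at least 19-fold lower number from compound 1 to compound 3 (1.28 log units; beyond the scatter), so trifluoromethyl stands apart from both earlier groups by steps beyond the scatter, and the change in the group on this carbon alone is enough to move the number substantially. The size of that second step remains a floor, as compound 1 carries a limit of the assay and not a number: the limit of > 20000 nM in this assay, at which 1 of the 3 values shown sits.

For the compounds shown here, the three compounds show that the choice of group on this carbon matters, but they do not show what about trifluoromethyl accounts for the step, and with only three groups no trend across substituents can be drawn. A chlorine atom, a nitrile or a methyl group on the same carbon would show whether the step belongs to trifluoromethyl alone, while a shorter or longer chain carrying the trifluoromethyl ring would show whether it holds outside the shared core.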